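The source may hold more compounds than are shown below. What is called first, only, known or untested is meant among the compounds shown, and "the series" means these compounds.

Measured compounds in an assay on isolated protein for inhibition of Dihydrofolate reductase (Homo sapiens), read by spectrophotometry, using NADPH, with stated times of 5 s and 6 min, tested at 50 uM; on this read-out higher numbers stand for a stronger effect at the one concentration tested and lower numbers for a weaker effect:

compound 1, `NC1=NC2(CCSCC2)N(OCCCOc2ccccc2Br)C(N)=N1`, gives 89.6%
compound 2, `NC1=NC2(CCSCC2)N(OCCCOc2cccc(Br)c2)C(N)=N1`, gives 86.5%

Compound 2 stands at the lower of the two numbers, but its nearest neighbour is compound 1, and the step of a number 3.1 percentage points lower from compound 1 to compound 2 (within the scatter) lies within the scatter, so the two compounds cannot be told apart on this read-out. Both inhibit strongly at the single concentration tested.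

The next compound, compound 3, `COc1ccc(OCCCON2C(N)=NC(N)=NC23CCSCC3)cc1`, has not been measured in this assay . Its difference from compound 2 is 4-methoxyphenyl in place of 3-bromophenyl on an oxygen on a saturated carbon. Within the data shown here, this is a different kind of change from the one step measured so far: that step moved a bromine from one position of the ring to another and changed nothing beyond the scatter, whereas here the bromine leaves altogether and a methoxy group on 4-methoxyphenyl enters. Among the measured compounds shown here, no measured step therefore bears directly on this change; the one step available, a number 3.1 percentage points lower from compound 1 to compound 2 (within the scatter), only shows that the ring tolerates a change in its substituent without loss.

On that basis compound 3 is expected to remain a strong inhibitor, with an estimated step of a number 6.5 percentage points lower from compound 2 to compound 3 (within the scatter). The estimate for compound 3 in this assay is 80%, ranging from 60% to 92%.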

Compound 3, a percentage reported as inhibition, at one concentration (the size of the read-out at that concentration, not a potency): 86.6%
Beside the measured number, compound 3's estimate is 6.6 percentage points below it; the range from low to high includes it.
By their numbers in this assay, from the lowest: compounds 2, 3 and 1 (each within the scatter of the next).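

In this assay, replacing 3-bromophenyl with 4-methoxyphenyl gives a number 0.1 percentage points higher from compound 2 to compound 3 (within the scatter), and replacing 2-bromophenyl with 4-methoxyphenyl gives a number 3 percentage points lower from compound 1 to compound 3 (within the scatter). The earlier step only moved a bromine around the ring, whereas these steps show that, on an oxygen on a saturated carbon, the bromine can be removed altogether and a methoxy group introduced with no difference that this read-out can separate from the scatter. No measurement is available to explain why this exchange leaves the number unchanged.

As far as these compounds go, all three numbers come from a single concentration, so they describe the size of the effect rather than potency, and any differences in potency among the three compounds remain open. Also open, from the compounds shown here alone, is how far this freedom extends, for example whether the same high inhibition would hold with an amine or a carboxylic acid on the ring, or with a plain alkyl chain in place of the whole substituted phenyl group.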